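Flipping Two Stereocentres on an Inactive Cyclobutane Diol

This account rests on a few compounds, and the source may have more. Where it says the series, first, only, none or still open, it means among the compounds named here.

All four compounds here share one core, a saturated ring bearing a methyl-substituted hydroxyl carbon, an aromatic group and a hydroxymethyl linked to a pyridine. They were studied in an assay on HEK293 cells for antagonist activity at transient receptor potential cation channel subfamily V member 3 (Homo sapiens), read by FLIPR and calcium flux; a lower number here means a stronger inhibitor, a higher number a weaker inhibitor. Compound 1 `C[C@]1(O)C[C@@](c2ccc(OC(F)(F)F)cc2)([C@@H](O)c2ccccn2)C1` sets the floor: in this assay compound 1 gives only a limit, > 10400 nM, with no number behind it. Two relatives carry a different aromatic group and a different drawn configuration at two centres. Compound 2 `C[C@]1(O)C[C@](c2ccnc(C(F)(F)F)c2)([C@H](O)c2ccccn2)C1` gives 500 nM in this assay, and compound 3 `C[C@]1(O)C[C@@](c2cccc(OC(F)(F)F)c2)([C@H](O)c2ccccn2)C1` gives 280 nM, two values close to each other.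

Compound 4 `C[C@]1(O)C[C@@](c2ccc(OC(F)(F)F)cc2)([C@H](O)c2ccccn2)C1` keeps every atom and bond of compound 1; the change is this: the two compounds have the same atoms and bonds and differ only in configuration as drawn: 2 of 3 stereo elements differ; a stereocentre at a saturated ring carbon is drawn S in compound 1 and R in compound 4; a stereocentre at a saturated chain carbon is drawn R in compound 1 and S in compound 4. Nothing leaves and nothing enters. Within the data shown here, since compound 1 shows only (the limit of > 10400 nM in this assay, at which 1 of the 3 values shown sits), no measured step is available to size this change, yet its sister compounds hint that configuration matters.

The expectation is that compound 4 gains potency and drops into the range of compounds 2 and 3 because compound 3 gives 280 nM with the same drawn configuration. The estimated step of an at least 17-fold lower number from compound 1 to compound 4 (1.23 log units; beyond the scatter) is therefore a large one in the direction of stronger inhibition. Compound 4 is expected to reach about 600 nM, likely between 150 nM and 3000 nM.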

Compound 4, antagonist equilibrium constant: 330 nM
For compound 4 the middle estimate is 1.8-fold (0.26 log units) above the measured one; the measured number falls inside the stated range.
By their numbers in this assay, from the lowest: compounds 3, 4 and 2 (each within the scatter of the next). At a limit, above all of these: compound 1.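

Compound 4 gives the first readable measure of what configuration alone does at these two stereocentres in this assay: the step is an at least 31-fold lower number from compound 1 to compound 4 (1.49 log units; beyond the scatter). Compound 1 gives only a limit, so the true size of this step may be larger than the printed figure: the limit of > 10400 nM in this assay, at which 1 of the 4 values shown sits. The gain can be assigned to configuration as drawn and to nothing else, because no atom or bond changes in this pair: the fact that compounds 1 and 4 differ only in the configuration as drawn.

The two stereocentres change together, so the compounds shown leave open whether the saturated ring carbon, the saturated chain carbon or only the pair of them in combination accounts for the step, and a compound with just one of the two centres changed would separate these cases. From the compounds shown here alone, it also remains open how this assay would respond to an amine in place of the hydroxyl on the saturated chain carbon, a swap that would test whether that hydroxyl matters in the configuration of compound 4.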